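The source may report more compounds than this note shows. Statements on the series, on what has been measured and on what is new or still open speak of the compounds shown alone.

Among the compounds with values here, compound 2 `NC(=O)c1c(NC(=O)c2ccc(C(F)(F)F)cc2)sc2c1CCN(C(=O)Nc1ccccc1Cl)C2` carries the highest number of the two measured so far in a functional assay on MKN-74 cells (Homo sapiens) for antiproliferative activity, with a stated time of 24 h; a higher number here means a weaker inhibitor, a lower number a stronger inhibitor: compound 2 gives 43900 nM, whereas compound 1 `Cc1ccc(C(=O)Nc2sc3c(c2C(N)=O)CCN(Cc2c(Cl)cccc2Cl)C3)cc1` gives 12300 nM, a gap beyond the scatter. These two differ in more than one place, so no single change can be read from that gap. Compound 3 `Cc1ccc(C(=O)Nc2sc3c(c2C(N)=O)CCN(C(=O)Nc2ccccc2Cl)C3)cc1` has not been measured yet; it differs from compound 2 by methyl in place of trifluoromethyl on an aromatic carbon, para to a large group. Within the data shown here, no measured pair isolates this change, so only a small step is expected, possibly none beyond the scatter. For compound 3 the expected value in this assay is 25000 nM, within 8000 nM to 70000 nM. That expectation corresponds to a step of a 1.8-fold lower number from compound 2 to compound 3 (0.24 log units; within the scatter).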

Compound 3, half-maximal inhibitory concentration: 27600 nM
Beside the measured number, compound 3's estimate is 1.1-fold (0.04 log units) below it, within the range that was stated.
By their numbers in this assay, from the lowest: compound 1; then compounds 3 and 2 (each within the scatter of the next).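

In this assay, methyl in place of trifluoromethyl on this aromatic carbon gives a 1.6-fold lower number from compound 2 to compound 3 (0.20 log units; within the scatter), so the two groups cannot be told apart here. Within the data shown here, compound 3 also gives the first single-place comparison on the amine nitrogen in a ring: (2-chlorophenyl)carbamoyl in place of 2,6-dichlorobenzyl gives a 2.2-fold higher number from compound 1 to compound 3 (0.35 log units; beyond the scatter), a modest step. No measurement available here explains either step.

Going by these compounds, whether an amine or a carboxylic acid on that aromatic carbon would shift the number remains open. So does the effect of a longer chain on the amine nitrogen.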